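A few compounds are considered here, and "the series" means these few. Any claim that something is new, unique, unknown or untested is made for them only; others in the source may bear on it.

Measured so far:
- compound 1 `O=C(Nc1c(C(O)(C(F)(F)F)C(F)(F)F)ccc2ccccc12)c1ccccc1Cl`: 2040 nM
- compound 2 `Cc1cccc(C(=O)Nc2c(C(O)(C(F)(F)F)C(F)(F)F)ccc3ccccc23)c1`: 23 nM
- compound 3 `O=C(Nc1c(C(O)(C(F)(F)F)C(F)(F)F)ccc2ccccc12)c1cccc(C(F)(F)F)c1`: 84 nM

In an assay on LtK cells with ATP-sensitive inward rectifier potassium channel 11 (Homo sapiens) as the target (on this read-out lower numbers stand for an effect already at smaller amounts and higher numbers for an effect only at larger amounts of compound), compound 1 stands highest of the three numbers, with compound 3 nearest and compound 2 furthest: a 24-fold lower number from compound 1 to compound 3 (1.39 log units; beyond the scatter) and an 89-fold lower number from compound 1 to compound 2 (1.95 log units; beyond the scatter). Compound 4 `O=C(Nc1c(C(O)(C(F)(F)F)C(F)(F)F)ccc2ccccc12)c1ccc(OC(F)(F)F)cc1` is not yet measured. Its change from compound 1: 4-(trifluoromethoxy)phenyl in place of 2-chlorophenyl on a carbonyl carbon.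

Among the measured compounds shown here, two measured steps bear on this one, as both also remove the 2-chlorophenyl from the carbonyl carbon in favour of a substituted phenyl: the step to compound 2 and the step to compound 3, each large and each toward lower numbers. The difference between those two replacements is only modest, a 3.7-fold higher number from compound 2 to compound 3 (0.56 log units; beyond the scatter), so the gain appears to lie chiefly in leaving the 2-chlorophenyl. For the measured compounds named here, no measured compound carries a 4-(trifluoromethoxy)phenyl, so the size of the step is less certain than its direction. A large lowering is therefore expected, a 14-fold lower number from compound 1 to compound 4 (1.13 log units; beyond the scatter), with compound 4 estimated at 150 nM in this assay, range 40 nM to 600 nM.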

Compound 4, half-maximal effective concentration: > 10000 nM
Compound 4 ended at the assay's limit; the forecaster's own chance of this, stated with the estimate: 2%; middle value at least 66-fold (1.82 log units) away from the limit.
By their numbers in this assay, from the lowest: compound 2; then compound 3; then compound 1. At a limit, above all of these: compound 4.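

Compound 4 stands at a limit, not at a number: the limit of > 10000 nM in this assay, at which 1 of the 4 values shown sits.

Leaving the 2-chlorophenyl on the carbonyl carbon is therefore no gain in itself: the earlier replacements gave an 89-fold lower number from compound 1 to compound 2 (1.95 log units; beyond the scatter) and a 24-fold lower number from compound 1 to compound 3 (1.39 log units; beyond the scatter), whereas 4-(trifluoromethoxy)phenyl reverses the direction, with an at least 4.9-fold higher number from compound 1 to compound 4 (0.69 log units; beyond the scatter). The entering group matters far more than the gap of a 3.7-fold higher number from compound 2 to compound 3 (0.56 log units; beyond the scatter) suggested, as there is an at least 110-fold higher number from compound 3 to compound 4 (2.07 log units; beyond the scatter) and an at least 430-fold higher number from compound 2 to compound 4 (2.63 log units; beyond the scatter).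

As far as these compounds go, whether the loss follows the trifluoromethoxy group or the placement of the substituent stays open, and a 3-(trifluoromethoxy)phenyl or a 4-methylphenyl would separate the two. Also open, from the compounds shown here alone, are how far compound 4 lies past its limit and how an amine or a carboxylic acid on this phenyl would read out.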